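A few compounds are considered here, and "the series" means these few. Any claim that something is new, unique, unknown or untested is made for them only; others in the source may bear on it.

Three compounds of one series were tested in a functional assay on U-87MG ATCC cells for antiproliferative activity against U-87 MG (Homo sapiens), read by MTT assay, with a stated time of 48 h, tested at 50 uM; on this read-out lower numbers stand for a stronger effect and higher numbers for a weaker effect at the one concentration tested. Compound 1 `COc1ccc(-c2nc(SCC(=O)c3sc(-c4ccccc4)nc3C)nc(N)c2C#N)cc1` gives 33.8%. Compound 2 `COc1ccc(-c2nc(C)c(C(=O)CSc3nc(-c4ccc(Cl)cc4)c(C#N)c(=O)[nH]3)s2)cc1` gives 48%. Compound 3 `Cc1nc(-c2ccccc2)sc1C(=O)CSc1nc(N)c(C#N)c(-c2ccccc2)n1` gives 26.3%, the lowest of the three numbers; its nearest neighbour is compound 1, within the scatter, and the furthest is compound 2, beyond the scatter. Within the data shown here, the only single-point step measured, a number 7.5 percentage points lower from compound 1 to compound 3 (within the scatter), concerns the same phenyl ring that is altered next, and it stayed within the scatter.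

Compound 4 `Cc1nc(-c2ccc(Cl)cc2)sc1C(=O)CSc1nc(N)c(C#N)c(-c2ccccc2)n1` has not yet been measured. It differs from compound 3 by chloro in place of hydrogen on an aromatic carbon. Among the measured compounds shown here, the one step that bears on it, from compound 1 to compound 3, replaced a substituent on this same ring and moved the read-out only within the scatter, so no step beyond the scatter is expected here either; compound 2 carries a chlorine too, but no single-point comparison links it to compound 3, and its value is simply higher. Compound 4 is therefore expected to lie near compound 3, with a number 1.7 percentage points higher from compound 3 to compound 4 (within the scatter), at about 28%, between 15% and 42%.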

Compound 4, a percentage reported as activity, at one concentration (the size of the read-out at that concentration, not a potency): 15.2%
The estimate for compound 4 lay 12.8 percentage points above the measured number, within the range that was stated.
By their numbers in this assay, from the lowest: compound 4; then compounds 3 and 1 (each within the scatter of the next); then compound 2.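

In this assay, among these compounds, the change from phenyl to 4-chlorophenyl gives a number 11.1 percentage points lower from compound 3 to compound 4 (beyond the scatter), the first single-point step in this set to lie beyond the scatter, so a chloro para to a large group on this ring strengthens the effect at the one concentration tested. The structures show that the earlier step, a number 7.5 percentage points lower from compound 1 to compound 3 (within the scatter), sits on the other phenyl ring rather than on this one, so it says nothing about this position, and this position responds where that change on the other ring did not move the read-out beyond the scatter. No measurement at hand accounts for the step.

Whether the effect is specific to chloro remains open, since the compounds shown do not tell how fluoro, bromo, trifluoromethyl or an amine would behave at this place. Also open, from the compounds shown here alone, is whether chloro would have the same effect at another place on this ring.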